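A few compounds are considered here, and "the series" means these few. Any claim that something is new, unique, unknown or untested is made for them only; others in the source may bear on it.

Measured so far in a functional assay on SK-MEL-2 cells (Homo sapiens) for inhibition, read by sulforhodamine B assay, with a stated time of 48 h; a lower number here means that less compound is tolerated, a higher number that more compound is tolerated:
Compound 1 `O=C(Nc1cccc(-n2cc(-c3ccncc3)c(-c3ccc(Cl)c(O)c3)n2)c1)Nc1cccc(C(F)(F)F)c1`: > 32500 nM (a limit)
Compound 2 `O=C(Nc1cccc(-n2cc(-c3ccncc3)c(-c3ccc(Cl)c(O)c3)n2)c1)Nc1ccc(Cl)c(Cl)c1`: > 32500 nM (a limit)

Compound 1 stands at the limit of > 32500 nM in this assay, at which 2 of the 2 values shown sit, so it offers a limit and not a number, and compound 2 offers no number either. Compound 3 `COc1cc(-c2nn(-c3cccc(NC(=O)Nc4cccc(C(F)(F)F)c4)c3)cc2-c2ccncc2)ccc1Cl` departs from compound 1 at a single place: methyl in place of hydrogen on an oxygen on an aromatic ring. This is hydroxy to methoxy, with methyl in place of hydrogen on an oxygen on an aromatic ring. Among the measured compounds shown here, the only measured step is a step that the two limits leave unreadable from compound 1 to compound 2. For the measured compounds named here, it concerns a different place, on an amide-type nitrogen, and no measured step touches the hydroxy group, so no size can be carried over. In this assay, a change beyond the scatter in either direction is therefore not expected. The expected step is a step that the limit leaves unreadable from compound 1 to compound 3. For compound 3 the estimated value is 35000 nM, with an expected range from 12000 nM to 60000 nM.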

Compound 3, concentration lethal to 50% of the cells: 3960 nM
Beside the measured number, compound 3's estimate is 8.8-fold (0.95 log units) above it; measured number below the stated range.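

In this assay, hydroxy to methoxy on the 4-chloro-3-hydroxyphenyl group gives an at least 8.2-fold lower number from compound 1 to compound 3 (0.91 log units; beyond the scatter), so this oxygen is a place where one added methyl moves the read-out beyond the scatter. The earlier step, on an amide-type nitrogen, could not be read, which makes compound 3 the first compound shown to give a number rather than a limit. The step's size is therefore a minimum and not an exact measure, since the starting value is a limit shared with compound 2: the limit of > 32500 nM in this assay, at which 2 of the 3 values shown sit.

Going by these compounds, whether the change depends on the added methyl or on the lost hydrogen stays open, as does what a longer chain such as ethoxy, or an amine in place of the oxygen, would give. Also open, on these data alone, is whether methoxy would have the same effect on compound 2, which carries the same hydroxy group.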